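The source may hold more compounds than are shown below. What is called first, only, known or untested is meant among the compounds shown, and "the series" means these compounds.

Compound 3 `CCOc1nc(N)c2nc(O)n(Cc3ccccc3)c2n1` stands at the top of the three numbers in a functional assay on the whole organism for activation, with Mus musculus as the target (a lower number here means that less compound is needed, a higher number that more compound is needed for the effect), where compound 3 gives 0.3 mg/kg. Compound 1 `CCCCc1nc(N)c2nc(O)n(Cc3ccccc3)c2n1` gives 0.3 mg/kg in this assay, and no change at the digits printed from compound 1 to compound 3 (within the scatter). Compound 2 `CCCCNc1nc(N)c2nc(O)n(Cc3ccccc3)c2n1` gives 0.1 mg/kg in this assay, and a 3.0-fold higher number from compound 2 to compound 3 (0.48 log units; beyond the scatter). So compound 3 sits level with compound 1, and the only measured separation beyond the scatter is the modest one to compound 2.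

Compound 4 `CCCOc1nc(N)c2nc(O)n(Cc3ccccc3)c2n1` differs from compound 3 by methyl in place of hydrogen on a saturated chain carbon, two bonds along the chain from an oxygen on an aromatic ring. Going by the values given here, no measured step adds a methyl to a chain in this way; the two steps that reach compound 3 replace the whole group on that aromatic carbon, one of them flat and the other modest. A lengthening of the ethoxy to propoxy is smaller than either of those swaps, and so no step beyond the scatter is expected in this assay. Compound 4 is therefore expected to give 0.3 mg/kg in this assay, within a range from 0.1 mg/kg to 1 mg/kg. That estimate for compound 4 amounts to no change at the digits printed from compound 3 to compound 4 (within the scatter).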

Compound 4, minimum effective dose: 0.3 mg/kg
Compound 4: middle estimate and measured number agree at the digits printed, and the stated range covers the measured number.
By their numbers in this assay, from the lowest: compound 2; then compounds 1, 3 and 4 (each within the scatter of the next).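

In this assay the lengthening of ethoxy to propoxy gives no change at the digits printed from compound 3 to compound 4 (within the scatter) and so shows that this saturated chain carbon, two bonds along the chain from an oxygen on an aromatic ring, accepts a methyl without a shift beyond the scatter. Propoxy in place of butyl gives no change at the digits printed from compound 1 to compound 4 (within the scatter) and so adds a third compound to the level group. Propoxy in place of butylamino gives a 3.0-fold higher number from compound 2 to compound 4 (0.48 log units; beyond the scatter) and so the separation seen with ethoxy persists, leaving compound 2 alone at the low end of these four numbers.

As far as these compounds go, whether a longer chain such as butoxy, a branched isopropoxy or an amine at the end of the chain would keep the number level stays open, as does whether the nitrogen or the chain length of butylamino sets compound 2 apart. No evidence at hand bears on why the added methyl leaves the number in place.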